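Chloro in Place of Methyl: Expecting the Next Result

This account rests on a few compounds, and the source may have more. Where it says the series, first, only, none or still open, it means among the compounds named here.

Compound 1, `CCOC(=O)c1c(-c2ccc(Cl)cc2)cc(-c2ccccc2)nc1N1CCCCC1`: 59.3%
Compound 2, `CCOC(=O)c1c(-c2ccc(Cl)cc2)cc(-c2ccccc2)nc1Nc1ccc(C)cc1`: 69.5%

Both compounds were tested in a functional assay on the whole organism (strain Wister albino) for inhibition, with Rattus norvegicus as the target, read by paw edema, with a stated time of 1 h, at a dose of 50 mg/kg by the intraperitoneal route; a lower number here means less inhibition, a higher number more inhibition at the dose given (going by the name of the read-out). Compound 1 gives 59.3% and compound 2 gives 69.5%, which makes compound 2 the higher of the two numbers shown, its one neighbour lying a number 10.2 percentage points higher from compound 1 to compound 2 (beyond the scatter). That single step is the only one measured, and it concerns the exchange of piperidin-1-yl for (4-methylphenyl)amino, not the part of compound 2 that is altered next.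

Compound 3, `CCOC(=O)c1c(-c2ccc(Cl)cc2)cc(-c2ccccc2)nc1Nc1ccc(Cl)cc1`, keeps the shared core of compound 2 and differs from it in one place: chloro in place of methyl on an aromatic carbon. For the measured compounds named here, no measured pair speaks to this exchange on the six-membered aromatic ring of carbon only, so the modest step from compound 1 to compound 2 is only a loose guide to the scale of movement seen. On that basis the estimated step from compound 2 to compound 3 in this assay is a number 1.5 percentage points lower from compound 2 to compound 3 (within the scatter), not beyond the scatter in either direction. Compound 3 is therefore expected to give about 68%, with a range from 55% to 80%.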

Compound 3, a percentage reported as inhibition, in the whole organism at one dose (the size of the read-out at that dose, not a potency): 44.6%
The estimate for compound 3 lay 23.4 percentage points above the measured number; the whole stated range lies above it.
By their numbers in this assay, from the lowest: compound 3; then compound 1; then compound 2.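

In this assay, the group on the aromatic carbon para to a large group proves to matter: exchanging methyl for chloro, one heavy atom for another with no hydrogen-bond donor or acceptor on either side, gives a number 24.9 percentage points lower from compound 2 to compound 3 (beyond the scatter) and is the largest step seen so far in the series. The benefit of an arylamino group over piperidin-1-yl is also not general, since (4-methylphenyl)amino had given a number 10.2 percentage points higher from compound 1 to compound 2 (beyond the scatter) while (4-chlorophenyl)amino in the same place gives a number 14.7 percentage points lower from compound 1 to compound 3 (beyond the scatter) in the opposite direction. For the compounds shown here, nothing at hand bears on why this single exchange moves the number so far, and the reason remains unknown.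

With only methyl and chloro shown on this ring, it remains open whether fluoro, methoxy or a plain hydrogen at the same place would stay near the higher number or the lower one, and so whether the fall is particular to chloro. From the compounds shown here alone, it is also open whether the order of the three compounds would hold at another dose or reading time, as all of them are compared under one set of conditions.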